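Swapping an acid for a pyrrolidine amide in compound 4

The source may report more compounds than this note shows. Statements on the series, on what has been measured and on what is new or still open speak of the compounds shown alone.

Compound 2 `CC(C)(Oc1ccc(NCc2cccc(Oc3ccccc3)c2)cc1)C(=O)O` stands only at a limit in a functional assay on CHO cells for agonist activity at Free fatty acid receptor 1 (Homo sapiens); a higher number here means that more compound is needed for the effect, a lower number that less compound is needed: compound 2 gives < 10000 nM, which is a limit of the assay and not a number. Compound 1 `Cc1nc(-c2ccc(C(F)(F)F)cc2)sc1CNc1ccc(CC(=O)O)cc1` likewise sits at a limit, giving < 10000 nM in this assay. Both share (the limit of < 10000 nM in this assay, at which 2 of the 3 values shown sit). Compound 3 `Cc1nc(-c2ccc(C(F)(F)F)cc2)sc1CNc1ccc(CCC(N)=O)cc1` gives 12.9 nM in this assay. The change from compound 2 to compound 4 `O=C(CCc1ccc(NCc2cccc(Oc3ccccc3)c2)cc1)N1CCCC1` is 2-((pyrrolidin-1-yl)carbonyl)ethyl in place of 1-carboxy-1-methylethoxy on an aromatic carbon. Among the measured compounds shown here, the one related step, a step that the limit leaves unreadable from compound 1 to compound 3, cannot be read because compound 1 sits at a limit, so no step size is known for this kind of change. Because compound 3 gives 12.9 nM in this assay, compound 4 is expected to reach about 150 nM, between 10 nM and 3000 nM. That expectation means a step that the limit leaves unreadable from compound 2 to compound 4, counted from a limit.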

Compound 4, half-maximal effective concentration: 115 nM
Estimate against measurement, compound 4: 1.3-fold (0.12 log units) above; the range from low to high includes it.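

Compound 2 sits at a limit and not at a number, so no step size can be read from compound 2 to compound 4. The compounds shown leave open how large the effect is of 2-((pyrrolidin-1-yl)carbonyl)ethyl in place of 1-carboxy-1-methylethoxy.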